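This account rests on a few compounds, and the source may have more. Where it says the series, first, only, none or still open, it means among the compounds named here.

Measured so far:
compound 1 `COc1ccc(C(N)=O)cc1S(=O)(=O)Nc1cccnc1`: 1490 nM
compound 2 `COc1ccc(Br)cc1S(=O)(=O)Nc1cccnc1`: 43 nM
compound 3 `COc1ccc(Cl)cc1S(=O)(=O)Nc1cncc(-c2ccc(Cl)cc2)c1`: 198 nM

In an assay on isolated protein for inhibition of alkaline phosphatase, tissue-nonspecific isozyme (Homo sapiens) (on this read-out higher numbers stand for weaker inhibition and lower numbers for stronger inhibition), compound 2 holds the lowest number of the three; compound 3 sits next, and compound 1 furthest away. Compound 4 `COC(=O)c1ccc(OC)c(S(=O)(=O)Nc2cccnc2)c1` is not yet measured. It differs from compound 2 in one place: methoxycarbonyl in place of bromo on an aromatic carbon. Among the measured compounds shown here, one measured step bears on this change. The step of a 35-fold lower number from compound 1 to compound 2 (1.54 log units; beyond the scatter) shows that putting bromo in place of a carbonyl-bearing group lowered the number sharply; compound 4 puts a carbonyl-bearing group back in place of bromo, so a rise is expected, though methoxycarbonyl is not carbamoyl and the size is uncertain. Compound 4 is therefore estimated at 400 nM, within 100 nM to 1500 nM, a step of a 9.3-fold higher number from compound 2 to compound 4 (0.97 log units; beyond the scatter).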

Compound 4, half-maximal inhibitory concentration: 1510 nM
Beside the measured number, compound 4's estimate is 3.8-fold (0.58 log units) below it, and the stated range ends below it.
By their numbers in this assay, from the lowest: compound 2; then compound 3; then compounds 1 and 4 (each within the scatter of the next).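

At the position para to a methoxy group, methoxycarbonyl gives up the gain seen with bromo, with a 35-fold higher number from compound 2 to compound 4 (1.55 log units; beyond the scatter) in this assay. Changing the group on the carbonyl carbon from amino to methoxy gives a 1.0-fold higher number from compound 1 to compound 4 (0.01 log units; within the scatter), so here the two carbonyl-bearing groups cannot be told apart. Nothing available explains either result.

On these data alone, whether the higher number goes with the carbonyl itself or with any replacement of bromo remains open. A carboxylic acid, a nitrile or a methyl group at this position on the same core would help separate the two.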